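The compounds below may be only part of what the source reports. "The series", "measured", "known", "first", "only" and "open" are said of these compounds alone.

In an ADME assay on HeLa cells (Homo sapiens) for cytotoxicity, read by MTT assay (a lower number here means that less compound is tolerated, a higher number that more compound is tolerated), two compounds have been measured so far. Compound 1 `Nn1c(Cc2ccccc2F)nnc1SCc1cc(=O)oc2cc(O)c(O)cc12` gives > 100000 nM, which is a limit of the assay and not a number. Compound 2 `COc1cc(/C=C2\SC(=S)N(c3cccc(Cl)c3)C2=O)cc(OC)c1O` gives > 100000 nM, which is likewise a limit. Among the compounds with values here, compound 2 thus stands at the limit of > 100000 nM in this assay, at which 2 of the 2 values shown sit, and no step between measured compounds is available to guide the next reading.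

Within the data shown here, compound 3 `COc1cc(/C=C2\SC(=S)N(c3ccc([N+](=O)[O-])cc3)C2=O)cc(OC)c1O` carries 4-nitrophenyl in place of 3-chlorophenyl on an amide-type nitrogen in a ring, the one change from compound 2: 4-nitrophenyl in place of 3-chlorophenyl on an amide-type nitrogen in a ring. Resting on the limit of compound 2 at > 100000 nM, no step beyond the scatter is expected in this assay, in either direction. The expected step of an at least 1.1-fold lower number from compound 2 to compound 3 (0.04 log units; that floor lies within the scatter) is an estimate that stays within the scatter. For compound 3 the estimated value is 90000 nM, with an expected range from 25000 nM to 150000 nM.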

Compound 3, half-maximal cytotoxic concentration: 11000 nM
The estimate for compound 3 lay 8.2-fold (0.91 log units) above the measured number, and the stated range ends above it.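

In this assay the group on this amide-type nitrogen in a ring proves able to move the reading: 4-nitrophenyl in place of 3-chlorophenyl gives an at least 9.0-fold lower number from compound 2 to compound 3 (0.95 log units; beyond the scatter) and leaves the rest of the molecule unchanged. Compound 3 is the first compound shown to give a number rather than a limit, so this one change brings the series within the measurable range. The step is a floor and not a full size, since the reading of compound 2 is a limit of the assay: (the limit of > 100000 nM in this assay, at which 2 of the 3 values shown sit).

Within the data shown here, the single pair does not separate the swap of chlorine for the nitro group from the shift in where the group sits on the phenyl ring. On these data alone, how 4-chlorophenyl, 3-nitrophenyl or 4-aminophenyl would read on the same nitrogen remains open.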